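Methyl for Hydrogen on the Phenyl of Compound 2

A few compounds are considered here, and "the series" means these few. Any claim that something is new, unique, unknown or untested is made for them only; others in the source may bear on it.

Going by the values given here, compound 2 `O=C1NC(O)(CCn2cc(-c3ccccc3)nn2)C(OCc2ccccc2)=C1OCc1ccccc1` is the only compound with a number in a functional assay on U-937 cells (Homo sapiens) for antiproliferative activity, read by MTT assay, with a stated time of 24 h (on this read-out lower numbers stand for stronger inhibition and higher numbers for weaker inhibition), where compound 2 gives 21500 nM. Compound 1 `O=C1O/C(=C\Cn2cc(Cc3ccccc3)nn2)C(OCc2ccccc2)=C1OCc1ccccc1` reaches only a limit of the assay in this assay, giving > 100000 nM. Compound 3 `Cc1ccc(-c2cn(CCC3(O)NC(=O)C(OCc4ccccc4)=C3OCc3ccccc3)nn2)cc1` differs from compound 2 by methyl in place of hydrogen on an aromatic carbon. Among the compounds with values here, no measured pair shows the size of such a step, so no shift beyond the scatter is expected in this assay, in either direction. Compound 3 is therefore estimated at 20000 nM in this assay, within 7000 nM to 60000 nM. That estimate means an expected 1.1-fold lower number from compound 2 to compound 3 (0.03 log units; within the scatter).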

Compound 3, half-maximal inhibitory concentration: 54000 nM
Compound 3: middle estimate off by 2.7-fold (0.43 log units), on the low side; low and high end bracket the measured number.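

Changing phenyl to 4-methylphenyl gives the first measured size for a change at this position: in this assay it brings a 2.5-fold higher number from compound 2 to compound 3 (0.40 log units; beyond the scatter). Even one added carbon on this ring therefore moves the read-out, and it moves it modestly towards weaker inhibition. Nothing measured here accounts for this step. The compounds shown leave open whether a methoxy group, a fluorine atom or an amine at the same place would shift the number in the same direction, and whether a longer chain would widen the step.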